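The source may hold more compounds than are shown below. What is called first, only, known or untested is meant among the compounds shown, and "the series" means these compounds.

Compound 1 `O=C(Nc1cccc(/C=C/C(=O)c2nc3ccccc3[nH]2)c1)c1cccc(Br)c1`: 5210 nM
Compound 2 `Cc1ccc(C(=O)Nc2cccc(/C=C/C(=O)c3nc4ccccc4[nH]3)c2)cc1`: 9690 nM
Compound 3 `O=C(/C=C/c1cccc(NS(=O)(=O)c2ccccc2Cl)c1)c1nc2ccccc2[nH]1`: 4280 nM

All three share a core and differ only in the group carried on the nitrogen attached to the aromatic ring. In a functional assay on MCF7 cells (Homo sapiens) for antiproliferative activity, read by MTT assay, with a stated time of 48 h (a lower number here means a stronger inhibitor, a higher number a weaker inhibitor), compound 3 gives the lowest of the three numbers, though its separation from compound 1 is small a 1.2-fold lower number from compound 1 to compound 3 (0.09 log units; within the scatter), so the two cannot be told apart; the gap to compound 2 is a modest one a 2.3-fold lower number from compound 2 to compound 3 (0.35 log units; beyond the scatter).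

Compound 4 `Cc1cc(C)cc(S(=O)(=O)Nc2cccc(/C=C/C(=O)c3nc4ccccc4[nH]3)c2)c1` is not yet measured. It keeps the sulfonamide of compound 3 and changes only the ring on the sulfonyl sulfur: 3,5-dimethylphenyl in place of 2-chlorophenyl on a sulfonyl sulfur.

Among the measured compounds shown here, no measured step alters a ring on a sulfonyl sulfur, so nothing bears on this change directly. The closest comparison is the exchange of one substituted phenyl for another on the carbonyl carbon, from compound 1 to compound 2, which stayed within the scatter a 1.9-fold higher number from compound 1 to compound 2 (0.27 log units; within the scatter). All three measured variations of this part of the molecule span only a narrow range in this assay. A step of no more than the scatter, in either direction, is therefore expected a 1.1-fold higher number from compound 3 to compound 4 (0.02 log units; within the scatter).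

For compound 4 the expected value in this assay is 4500 nM, estimated to lie between 1800 nM and 11000 nM.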

Compound 4, half-maximal inhibitory concentration: 4570 nM
The estimate for compound 4 lay 1.0-fold (0.01 log units) below the measured number; low and high end bracket the measured number.
By their numbers in this assay, from the lowest: compounds 3, 4, 1 and 2 (each within the scatter of the next, the first and the last beyond it).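

Compound 3 and compound 4 are the only pair shown that differs in the ring on the sulfonyl sulfur, and in this assay the step is a 1.1-fold higher number from compound 3 to compound 4 (0.03 log units; within the scatter). Among the compounds shown here, this is the first direct look at that position: a phenyl ring carrying chlorine and a phenyl ring carrying two methyl groups cannot be told apart in this assay, even though the entering ring holds no halogen. The sulfonamide series therefore keeps its number within the scatter across this exchange, but no measurement here explains why the two rings read alike.

Only these two substituted phenyl rings are shown on the sulfonyl sulfur, so it remains open whether a simple methyl, a longer alkyl chain, or a phenyl ring bearing an amine or a carboxylic acid would stay within the same narrow range. Whether any group on the nitrogen or the sulfonyl sulfur could shift the number much further in this assay also stays open, as the widest gap shown is still only a 2.3-fold lower number from compound 2 to compound 3 (0.35 log units; beyond the scatter).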